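Swapping bromo for cyano on a slowly cleared compound

This account rests on a few compounds, and the source may have more. Where it says the series, first, only, none or still open, it means among the compounds named here.

In an ADME assay on the whole organism (Mus musculus, strain CD-1) for pharmacokinetics (a higher number here means faster removal of the compound, a lower number slower removal), compound 2 (`CCSc1cc([C@](O)(CCN(C)C)[C@@H](c2cc3cc(Br)ccc3nc2OC)c2cccc(OC)c2F)cc(SCC)n1`) gives 3.6 mL/min/kg and stands lowest of the two measured compounds. Compound 1 (`COc1cc([C@](O)(CCN(C)C)[C@@H](c2cc3cc(C#N)ccc3nc2OC)c2cccc(OC)c2F)cc(SC)n1`) gives 42 mL/min/kg in this assay as well, a gap that lies beyond the scatter. Among the compounds with values here, these two compounds differ in more than one place, so no measured step isolates a single change.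

Compound 3 (`CCSc1cc([C@](O)(CCN(C)C)[C@@H](c2cc3cc(C#N)ccc3nc2OC)c2cccc(OC)c2F)cc(SCC)n1`) is compound 2 with cyano in place of bromo on an aromatic carbon, and the rest of the structure stays as it is. Compound 1 also carries the cyano group, and because compound 1 gives 42 mL/min/kg a rise in this assay is expected here. That rise is expected to be moderate and only a little beyond the scatter, since the data cannot say how much of the gap belongs to this one place. The step expected is a 2.8-fold higher number from compound 2 to compound 3 (0.44 log units; beyond the scatter) on this estimate. For compound 3 the estimated clearance is 10 mL/min/kg with an expected range of 4 mL/min/kg to 25 mL/min/kg in all.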

Compound 3, clearance: 29 mL/min/kg
Compound 3: the middle estimate sits 2.9-fold (0.46 log units) below what was measured; the measured number lies above the stated range.
By their numbers in this assay, from the lowest: compound 2; then compounds 3 and 1 (each within the scatter of the next).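

The exchange of bromo for cyano on the aromatic carbon can now be read alone: in this assay it gives an 8.1-fold higher number from compound 2 to compound 3 (0.91 log units; beyond the scatter) and lies beyond the scatter, so this one place, meta and para to the fused ring, clearly moves the number when the rest of the structure stays fixed. With the cyano group held in place, the group of 12 heavy atoms in place of the group of 10 heavy atoms on the saturated chain carbon gives a 1.4-fold lower number from compound 1 to compound 3 (0.16 log units; within the scatter), which lies within the scatter, so this assay does not separate these two groups in this cyano pair. Nothing measured here explains why the exchange on the aromatic carbon has this size.

The compounds shown leave open whether bromo in place of cyano on the core of compound 1 would give a step of similar size, since this exchange is seen in one pair only. They also leave open where other groups at this place, such as chloro, methoxy or an amine, would fall in this assay relative to bromo and cyano.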